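The source may hold more compounds than are shown below. What is called first, only, known or untested is meant among the compounds shown, and "the series" means these compounds.

Working notes on the series. Compound 2 `O=C(CSc1nnc(-c2ccncc2)o1)N/N=C/c1ccc([N+](=O)[O-])cc1` in an ADME assay on NIH3T3 cells (Mus musculus) for cytotoxicity, read by MTT assay, with a stated time of 24 h (a higher number here means a weaker inhibitor, a lower number a stronger inhibitor), gives 195000 nM. Within the data shown here, the only other measured member, compound 1 `O=C(CSc1nnc(-c2ccncc2)o1)N/N=C/c1ccc(F)cc1`, in this assay gives 170000 nM, and the two numbers lie within the scatter of each other, so compound 2 cannot be set apart from compound 1 on this read-out. Among the measured compounds shown here, the single measured step, a 1.1-fold higher number from compound 1 to compound 2 (0.06 log units; within the scatter), is the only guide available for this ring.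

The next compound, compound 3 `O=C(CSc1nnc(-c2ccncc2)o1)N/N=C/c1ccc(O)cc1`, differs from compound 2 by hydroxy in place of nitro on an aromatic carbon. For the measured compounds named here, no measured step covers a hydroxy group at this place. Going by the values given here, the one step that does touch this place, a 1.1-fold higher number from compound 1 to compound 2 (0.06 log units; within the scatter), stayed within the scatter, which suggests that exchanging the group here changes little in this assay. Among the compounds with values here, a step beyond the scatter is therefore not expected for compound 3, and the uncertainty of the range reflects that no hydroxy analogue has been measured. Compound 3 is estimated at 185000 nM in this assay, with a range of 90000 nM to 380000 nM. This corresponds to an expected step of a 1.1-fold lower number from compound 2 to compound 3 (0.02 log units; within the scatter).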

Compound 3, half-maximal inhibitory concentration: 158000 nM
Compound 3: the middle estimate sits 1.2-fold (0.07 log units) above what was measured; low and high end bracket the measured number.
By their numbers in this assay, from the lowest: compounds 3, 1 and 2 (each within the scatter of the next).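

In this assay, the change from 4-nitrophenyl to 4-hydroxyphenyl adds a hydrogen-bond donor and removes the double bond outside aromatic rings, and it still amounts only to a 1.2-fold lower number from compound 2 to compound 3 (0.09 log units; within the scatter). The comparison with the fluoro analogue reads the same way, at a 1.1-fold lower number from compound 1 to compound 3 (0.03 log units; within the scatter), so fluoro, nitro and hydroxy on this aromatic carbon, para to a large group, cannot be told apart on this read-out, and the earlier suggestion from a single pair now rests on three compounds. Nothing at hand explains why these exchanges leave the number within the scatter.

As far as these compounds go, whether this insensitivity extends beyond these three groups stays open: an amine, a carboxylic acid or a longer chain such as butoxy at the same place could still produce a step beyond the scatter. From the compounds shown here alone, it is equally open whether the same exchanges would stay within the scatter on a changed core, since all three compounds share the core of compound 1 and vary only at this one place.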